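The source may report more compounds than this note shows. Statements on the series, on what has been measured and on what is new or still open speak of the compounds shown alone.

Measured so far in a functional assay on HeLa cells (Homo sapiens) for cytotoxicity, read by MTT assay, with a stated time of 72 h; a higher number here means a weaker inhibitor, a lower number a stronger inhibitor:

- Compound 1 `CC(C)(C)C1=CC(=O)C=C(NCC(=O)O)C1=O` gives 132000 nM
- Compound 2 `CC(C)[C@@H](NC1=CC(=O)C=C(C(C)(C)C)C1=O)C(=O)O` gives 96600 nM
- Compound 3 `CC1=CCC[C@H]2[C@](C)(CC3=CC(=O)C=C(N[C@@H](C(=O)O)C(C)C)C3=O)[C@@H](C)CC[C@]12C` gives 10900 nM

Compound 1 stands at the high end of these three numbers, level with compound 2 within the scatter, while compound 3 lies clearly lower. A lower number here means a stronger inhibitor, so compound 3 is the strongest of the three only in comparison with these two.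

The next compound to be measured is compound 4 `C[C@H](NC1=CC(=O)C=C(C(C)(C)C)C1=O)C(=O)O`. It differs from compound 1 by one small change, (methyl in place of hydrogen on a saturated chain carbon bound to an amine nitrogen and a carbonyl carbon), with methyl in place of hydrogen on a saturated chain carbon bound to an amine nitrogen and a carbonyl carbon.

For the measured compounds named here, one measured step bears on this change. At that same place, isopropyl in place of hydrogen gave a 1.4-fold lower number from compound 1 to compound 2 (0.14 log units; within the scatter). Compound 3 differs from compound 1 in more than one place, so it gives no direct guide. Going by the values given here, with only that single step to go on, and that step within the scatter, methyl is expected to leave the number essentially unchanged, with no step beyond the scatter. The estimated step is a 1.1-fold lower number from compound 1 to compound 4 (0.06 log units; within the scatter). For compound 4 the estimated value is 115000 nM, with an expected range from 60000 nM to 210000 nM.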

Compound 4, half-maximal inhibitory concentration: 89100 nM
Estimate against measurement, compound 4: 1.3-fold (0.11 log units) above, and the stated range covers the measured number.
By their numbers in this assay, from the lowest: compound 3; then compounds 4, 2 and 1 (each within the scatter of the next).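

In this assay, methyl in place of hydrogen on a saturated chain carbon bound to an amine nitrogen and a carbonyl carbon gives a 1.5-fold lower number from compound 1 to compound 4 (0.17 log units; within the scatter) and so joins isopropyl, which gave a 1.4-fold lower number from compound 1 to compound 2 (0.14 log units; within the scatter) at the same place. This position now has two different groups on it, and neither moves the number beyond the scatter, so neither the single carbon of methyl nor the larger isopropyl separates from hydrogen in this assay. These two steps describe only these groups on this one core, and nothing shown explains why the numbers stay so close.

What the compounds shown leave open is whether any group at this place can shift the number beyond the scatter, for example a phenyl ring, a hydroxymethyl group or a longer chain ending in an amine. For the compounds shown here, they also leave open how the mirror-image arrangement at this carbon would compare, since compound 2 and compound 4 each show only one arrangement of the groups there.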